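The compounds below may be only part of what the source reports. "The series", "measured", "known", "first", "only" and "open" are said of these compounds alone.

Measured in a functional assay on MGC-803 cells (Homo sapiens) for cytotoxicity, read by MTT assay, with a stated time of 38 h; a higher number here means a weaker inhibitor, a lower number a stronger inhibitor:
Compound 1 `COc1cc(OC)c2c(=O)c(OCCCCN3CCCC3)c(-c3cc(OC)c(OC)c(OC)c3)oc2c1` gives 18600 nM
Compound 2 `COc1cc(OC)c2c(=O)c(OCC(=O)N/N=C/c3ccccc3F)c(-c3cc(OC)c(OC)c(OC)c3)oc2c1` gives 2780 nM

Of these two numbers, the lower belongs to compound 2, so it is the stronger inhibitor of the pair in this assay. Compound 3 `COc1cc(OC)c2c(=O)c(OCC(=O)N/N=C/c3ccccn3)c(-c3cc(OC)c(OC)c(OC)c3)oc2c1` has not yet been measured. It differs from compound 2 at one place, with pyridin-2-yl in place of 2-fluorophenyl on a carbon with a double bond to nitrogen. For the measured compounds named here, only one measured step is available, a 6.7-fold lower number from compound 1 to compound 2 (0.83 log units; beyond the scatter). That modest step exchanged a different group at a different place, so it does not test this swap and gives no direction for it. No step beyond the scatter is therefore expected, and the value of compound 2 remains the best guide. The estimated change is a 1.1-fold higher number from compound 2 to compound 3 (0.03 log units; within the scatter). For compound 3 the expected value is 3000 nM, with an estimated range from 1000 nM to 9000 nM.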

Compound 3, half-maximal inhibitory concentration: 15300 nM
For compound 3 the middle estimate is 5.1-fold (0.71 log units) below the measured one; the measured number lies above the stated range.
By their numbers in this assay, from the lowest: compound 2; then compounds 3 and 1 (each within the scatter of the next).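

In this assay the group on the carbon with a double bond to nitrogen proves to matter, since pyridin-2-yl in place of 2-fluorophenyl gives a 5.5-fold higher number from compound 2 to compound 3 (0.74 log units; beyond the scatter) and so this single swap counts for about as much as the earlier change of the whole chain, a 6.7-fold lower number from compound 1 to compound 2 (0.83 log units; beyond the scatter) in size. The chain carrying pyridin-2-yl also stands level with the chain of compound 1, at a 1.2-fold lower number from compound 1 to compound 3 (0.08 log units; within the scatter) within the scatter, so in this series that chain does not lower the number without 2-fluorophenyl on it. Nothing available accounts for the difference between the two groups.

Because the swap removes the fluorine and brings in the ring nitrogen in one step, the compounds shown do not separate these two parts of the change. On these data alone, whether plain phenyl or 2-chlorophenyl at this place would lie nearer compound 2 or compound 3 remains open.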